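The source may report more compounds than this note shows. Statements on the series, on what has been measured and on what is new or still open speak of the compounds shown alone.

In a functional assay on Huh-7 cells (Homo sapiens) for inhibition, read by MTT assay, with a stated time of 48 h (a lower number here means a stronger inhibitor, a higher number a weaker inhibitor), compound 1 `COc1ccc2c(=O)c(/C=C/C(=O)Nc3cccc(C)c3)coc2c1` gives 15500 nM against compound 2 `COc1ccc2c(=O)c(/C=C/C(=O)NCc3ccccc3)coc2c1` at 13600 nM and compound 3 `COc1ccc2c(=O)c(/C=C/C(=O)Nc3ccccc3)coc2c1` at 9050 nM and all three lie within the scatter of one another. Compound 4 `COc1ccc2c(=O)c(/C=C/C(=O)NCc3ccc(F)cc3)coc2c1` is still unmeasured. Its change from compound 1 is 4-fluorobenzyl in place of 3-methylphenyl on an amide-type nitrogen with 4-fluorobenzyl in place of 3-methylphenyl on an amide-type nitrogen. The closest measured change is a 1.1-fold lower number from compound 1 to compound 2 (0.06 log units; within the scatter) for benzyl in place of 3-methylphenyl, while a 1.7-fold lower number from compound 1 to compound 3 (0.23 log units; within the scatter) and a 1.5-fold lower number from compound 2 to compound 3 (0.18 log units; within the scatter) are also small. Within the data shown here, no measured compound carries the fluorine, so no step beyond the scatter is expected in this assay here. An estimated 1.2-fold lower number from compound 1 to compound 4 (0.08 log units; within the scatter) is the expected step. Compound 4 is estimated at 13000 nM with 6500 nM to 26000 nM as the expected range.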

Compound 4, half-maximal inhibitory concentration: 21000 nM
Beside the measured number, compound 4's estimate is 1.6-fold (0.21 log units) below it; low and high end bracket the measured number.
By their numbers in this assay, from the lowest: compounds 3, 2, 1 and 4 (each within the scatter of the next, the first and the last beyond it).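

In this assay the series now holds its first step beyond the scatter, a 2.3-fold higher number from compound 3 to compound 4 (0.37 log units; beyond the scatter), a modest step for 4-fluorobenzyl in place of phenyl on the amide-type nitrogen. Fluoro in place of hydrogen on an aromatic carbon gives a 1.5-fold higher number from compound 2 to compound 4 (0.19 log units; within the scatter) and 4-fluorobenzyl in place of 3-methylphenyl gives a 1.4-fold higher number from compound 1 to compound 4 (0.13 log units; within the scatter), so both of these steps stay within the scatter. Among these compounds, nothing available explains the one step beyond the scatter.

From the compounds shown here alone, whether a longer chain on the amide-type nitrogen, or an amine or a carboxylic acid on its aromatic ring, would give a step beyond the scatter remains open.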